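A few compounds are considered here, and "the series" means these few. Any claim that something is new, unique, unknown or untested is made for them only; others in the source may bear on it.

Compound 1, `ClCc1ccc(Cn2cnc3c(Cl)ncnc32)cc1`, is one of three benzyl-linked analogues on a shared core that were tested in a functional assay on OVCAR-4 cells (Homo sapiens) for cytotoxicity, read by sulforhodamine B assay, with a stated time of 48 h (on this read-out lower numbers stand for stronger inhibition of growth and higher numbers for weaker inhibition of growth), where compound 1 gives 2450 nM. Compound 2, `ClCc1cccc(Cn2cnc3ncnc(Cl)c32)c1`, gives 4160 nM in this assay, and compound 3, `ClCc1ccccc1Cn1cnc2ncnc(Cl)c21`, gives 4890 nM. Compound 1 thus has the lowest of the three numbers, but both other values lie within the scatter of it, so none of the three can be set apart from the others on these data alone.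

Compound 4, `ClCc1ccc(Cn2cnc3c(Cl)nc(Cl)nc32)cc1`, has not yet been measured. It differs from compound 1 by chloro in place of hydrogen on an aromatic carbon, that is, a chloro in place of hydrogen on an aromatic carbon of the core, at the position between two ring nitrogen atoms. Among the compounds with values here, no pair of measured compounds shows the effect of this change, so no step can be drawn from the data for it. The step from compound 1 to compound 4 in this assay is expected to be small, in either direction, and probably not beyond the scatter, giving a 1.2-fold lower number from compound 1 to compound 4 (0.09 log units; within the scatter). The value of compound 4 in this assay is therefore estimated at 2000 nM, within a range from 700 nM to 6000 nM.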

Compound 4, concentration for 50% growth inhibition: 4900 nM
Compound 4: middle estimate off by 2.5-fold (0.39 log units), on the low side; low and high end bracket the measured number.
By their numbers in this assay, from the lowest: compounds 1, 2, 3 and 4 (each within the scatter of the next).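

With a single chloro in place of hydrogen on an aromatic carbon, between two ring nitrogen atoms, this assay shows a 2.0-fold higher number from compound 1 to compound 4 (0.30 log units; within the scatter). Within the data shown here, this is the first step that reads this position directly, and it shows that adding a chloro here leaves the number of compound 4 within the scatter of that of compound 1, so this one change gives no measurable separation. No measured evidence on the compounds bears on this result.

The compounds shown leave open whether an amine, a methoxy group or a longer chain at this same position would also stay within the scatter of compound 1. They also leave open whether the same chloro would give a similar step on compound 2 or compound 3.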